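Trifluoromethyl step from compound 1, working notes

This account rests on a few compounds, and the source may have more. Where it says the series, first, only, none or still open, it means among the compounds named here.

For the measured compounds named here, compound 1 `Nc1ncc(-c2ccccc2)c(-c2ccccc2)n1` gives 32% in an assay on CHO cells for displacement of a labelled ligand from adenosine receptor A1 (Homo sapiens), read by scintillation counting, with a stated time of 1 h, tested at 1 uM (on this read-out lower numbers stand for less inhibition and higher numbers for more inhibition at the one concentration tested (going by the name of the read-out)), the higher of the two numbers measured so far. Going by the values given here, compound 2 `COc1ccccc1-c1cnc(N)nc1-c1ccccc1` gives 20% in this assay; the single measured step, a number 12 percentage points lower from compound 1 to compound 2 (beyond the scatter), is methoxy in place of hydrogen on an aromatic carbon. Compound 3 `Nc1ncc(-c2ccc(C(F)(F)F)cc2)c(-c2ccccc2)n1` is not yet measured. It differs from compound 1 by trifluoromethyl in place of hydrogen on an aromatic carbon. Among the compounds with values here, no measured step involves a trifluoromethyl, and the one step available concerns a methoxy, so it bears on this change only loosely; it shows that a single added group on an aromatic carbon of this core can lower the number modestly. A step of similar size downward, or none beyond the scatter, is expected in this assay. Compound 3 is therefore estimated at 25%, with a range from 5% to 45%, meaning an expected step of a number 7 percentage points lower from compound 1 to compound 3 (within the scatter).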

Compound 3, a percentage reported as inhibition, at one concentration (the size of the read-out at that concentration, not a potency): 51%
Beside the measured number, compound 3's estimate is 26 percentage points below it, and the stated range ends below it.
By their numbers in this assay, from the lowest: compound 2; then compound 1; then compound 3.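

In this assay, for the compounds shown here, the trifluoromethyl change gives a number 19 percentage points higher from compound 1 to compound 3 (beyond the scatter), the first upward step, on an aromatic carbon of a six-membered aromatic ring of carbon only, para to a large group. Set against a number 12 percentage points lower from compound 1 to compound 2 (beyond the scatter), it shows that a single group added to an aromatic carbon of the shared core can move the number in either direction, so the downward methoxy step does not hold for every substituent. No supporting measurement bears on why the number rises with this change.

The compounds shown hold no other group at this place, so it remains open whether a chlorine atom, an amine or a carboxylic acid there would also raise the number. As far as these compounds go, with one tested concentration, the potency of compound 3 also remains open.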